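The source may hold more compounds than are shown below. What is called first, only, known or untested is meant among the compounds shown, and "the series" means these compounds.

In an assay on brain for displacement of a labelled ligand from 5-hydroxytryptamine receptor 4 (Cavia porcellus), with a stated time of 30 min, in the presence of a further agent that is not named here (a lower number here means a stronger inhibitor, a higher number a weaker inhibitor), compound 1 `COc1ccc(S(=O)(=O)NCCN2CCC(CCC(=O)c3cc(Cl)c(N)cc3OC)CC2)cc1Cl` gives 22.5 nM and compound 2 `COc1cc(N)c(Cl)cc1C(=O)CCC1CCN(CCNS(=O)(=O)c2cc(Br)c(N)c(Br)c2)CC1` gives 8.7 nM, the lowest of the two numbers. Among the measured compounds shown here, the single measured step, a 2.6-fold lower number from compound 1 to compound 2 (0.41 log units; beyond the scatter), arose from swapping the aryl group on the sulfonyl sulfur. Compound 3 `COc1ccc(S(=O)(=O)NCCN2CCC(CCC(=O)c3cc(Cl)c(N)cc3OC)CC2)cc1` differs from compound 2 at that same place: 4-methoxyphenyl in place of 4-amino-3,5-dibromophenyl on a sulfonyl sulfur. For the measured compounds named here, that step is the only guide, and it ran towards a lower number when the 4-amino-3,5-dibromophenyl entered, so removing it is expected to give a modestly higher number, a 3.4-fold higher number from compound 2 to compound 3 (0.54 log units; beyond the scatter), even though the entering 4-methoxyphenyl is not the group found in compound 1. Compound 3 is therefore estimated at 30 nM, within 12 nM to 80 nM.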

Compound 3, inhibition constant: 12.3 nM
Compound 3: middle estimate off by 2.4-fold (0.39 log units), on the high side; low and high end bracket the measured number.
By their numbers in this assay, from the lowest: compounds 2, 3 and 1 (each within the scatter of the next, the first and the last beyond it).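

With 4-methoxyphenyl in place of 4-amino-3,5-dibromophenyl on the sulfonyl sulfur, this assay shows a 1.4-fold higher number from compound 2 to compound 3 (0.15 log units; within the scatter), so two quite different aryl groups cannot be told apart at this place. Hydrogen in place of chloro on the aromatic carbon gives a 1.8-fold lower number from compound 1 to compound 3 (0.26 log units; within the scatter), so that single change cannot be told from scatter either, and compound 3 sits within the scatter of both earlier compounds. No measurement on hand speaks to what lies behind these numbers. As far as these compounds go, how a plain methyl group or a carboxylic acid on the phenyl ring would fare on the sulfonyl sulfur remains open.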